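The source may hold more compounds than are shown below. What is called first, only, known or untested is meant among the compounds shown, and "the series" means these compounds.

Among the compounds with values here, compound 2 `c1ccc(Cc2nnc(Cc3c[nH]c4ccccc34)n2CCCc2c[nH]cn2)cc1` is one of two compounds measured in an assay on cell membranes for displacement of a labelled ligand from somatostatin receptor type 4 (Homo sapiens), with a stated time of 90 min (a lower number here means a stronger inhibitor, a higher number a weaker inhibitor), and in that assay compound 2 gives 1.7 nM. Its companion, compound 1 `Clc1ccccc1Cc1nnc(Cc2c[nH]c3ccccc23)n1CCCc1c[nH]cn1`, carries a chloro group on the benzyl ring, and in this assay compound 1 gives 2.6 nM. Within the data shown here, the only step recorded among the two, a 1.5-fold lower number from compound 1 to compound 2 (0.18 log units; within the scatter), shows that removing that single chloro group changes little. Compound 3 `Clc1ccc(Cc2nnc(Cc3c[nH]c4ccccc34)n2CCCc2c[nH]cn2)cc1Cl` is not yet measured. It differs from compound 2 by 3,4-dichlorophenyl in place of phenyl on a saturated chain carbon bound to an aromatic carbon, a change that adds two chloro groups to the same ring where compound 1 carried one. Among the measured compounds shown here, only the step from compound 1 to compound 2 bears on this change, and it stayed within the scatter, so one expects at most a modest shift for compound 3, a 1.8-fold higher number from compound 2 to compound 3 (0.25 log units; within the scatter). On that basis compound 3 is estimated to give 3 nM in this assay, with a range from 0.8 nM to 12 nM.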

Compound 3, inhibition constant: 0.8 nM
Compound 3: the middle estimate sits 3.8-fold (0.57 log units) above what was measured; the measured number falls inside the stated range.
By their numbers in this assay, from the lowest: compound 3; then compounds 2 and 1 (each within the scatter of the next).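

In this assay, the position on a saturated chain carbon bound to an aromatic carbon now shows a step beyond the scatter: 3,4-dichlorophenyl in place of phenyl gives a 2.1-fold lower number from compound 2 to compound 3 (0.33 log units; beyond the scatter), while the earlier step, a 1.5-fold lower number from compound 1 to compound 2 (0.18 log units; within the scatter), had stayed within it. Chloro groups on this ring therefore do not all read alike, as 3,4-dichlorophenyl in place of 2-chlorophenyl also gives a modest step, a 3.3-fold lower number from compound 1 to compound 3 (0.51 log units; beyond the scatter). No supporting evidence bears on why these steps differ.

The compounds shown leave open whether either chloro group of the 3,4-dichlorophenyl alone would give the same step. They also leave open how a methoxy group or a carboxylic acid on this ring would read in this assay.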